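Benzofuran for phenyl on the nucleoside core of compound 2

The compounds below may be only part of what the source reports. "The series", "measured", "known", "first", "only" and "open" are said of these compounds alone.

Measured compounds:
Compound 1 `COc1nc(N)nc2c1c(-c1cc3ccccc3o1)cn2[C@@H]1O[C@H](CO)[C@@H](O)[C@H]1O` — 16700 nM
Compound 2 `Nc1nc2c(c(-c3ccccc3)cn2[C@@H]2O[C@H](CO)[C@@H](O)[C@H]2O)c(=O)[nH]1` — > 20000 nM
Compound 3 `COc1ncnc2c1c(-c1ccoc1)cn2[C@@H]1O[C@H](CO)[C@@H](O)[C@H]1O` — > 20000 nM

In a functional assay on CEM-DNR-bulk cells (Homo sapiens), read by MTT assay, with a stated time of 72 h (a lower number here means a stronger inhibitor, a higher number a weaker inhibitor), compound 1 gives 16700 nM, a number and not a limit. In this assay compound 2 gives only a limit, > 20000 nM. In this assay compound 3 likewise gives only a limit, > 20000 nM. As far as these compounds go, compound 2 thus stands at the limit of > 20000 nM in this assay, at which 2 of the 3 values shown sit, and its exact position below that mark is unknown.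

The next compound, compound 4 `Nc1nc2c(c(-c3cc4ccccc4o3)cn2[C@@H]2O[C@H](CO)[C@@H](O)[C@H]2O)c(=O)[nH]1`, is not yet measured. Going from compound 2 to compound 4 the change is 1-benzofuran-2-yl in place of phenyl on an aromatic carbon. Compound 1 carries the same 1-benzofuran-2-yl group on a different core and in this assay reaches a number rather than a limit, though a weak one. Within the data shown here, no measured step for this change exists. The expected step of a number no higher from compound 2 to compound 4 (the limit leaves the size open) is therefore none beyond the scatter, with compound 4 most likely remaining at or near the limit. Compound 4 is estimated at 20000 nM, with a range from 8000 nM to 50000 nM.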

Compound 4, half-maximal inhibitory concentration: > 20000 nM
Compound 4 ended at the assay's limit; the forecaster's own chance of this, stated with the estimate: 60%; the middle value lies on the limit itself.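

No step can be read from compound 2 to compound 4 in this assay, because both compounds give only a limit and not a number: the limit of > 20000 nM in this assay, at which 3 of the 4 values shown sit.

The compounds shown leave open whether 1-benzofuran-2-yl in place of phenyl changes activity on this core at all.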